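The compounds below may be only part of what the source reports. "The series", "measured", "known", "first", "only" and "open" are said of these compounds alone.

Of the compounds shown here, three sharing one core have been measured in a functional assay on BJAB cells (Homo sapiens) for antiproliferative activity, with a stated time of 4 days; on this read-out lower numbers stand for an effect already at smaller amounts and higher numbers for an effect only at larger amounts of compound. Compound 1 `CC(=O)Nc1ccc(-c2c(C)nn(-c3nc(-c4ccc(Cl)c(Cl)c4)c(SC(C)C)s3)c2C(=O)O)cc1` gives 139000 nM in this assay. Compound 2 `Cc1nn(-c2nc(-c3ccc(Cl)c(Cl)c3)c(SC(C)C)s2)c(C(=O)O)c1-c1cc(C#N)cc(C(F)(F)F)c1` gives 3600 nM in this assay. Compound 3 `Cc1cc(-c2c(C)nn(-c3nc(-c4ccc(Cl)c(Cl)c4)c(SC(C)C)s3)c2C(=O)O)cc(C)n1` gives 580 nM in this assay. Among these three numbers compound 3 stands lowest: the steps of a 240-fold lower number from compound 1 to compound 3 (2.38 log units; beyond the scatter) and a 6.2-fold lower number from compound 2 to compound 3 (0.79 log units; beyond the scatter) both lie beyond the scatter, so compound 3 acts at smaller amounts than either of the others.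

Compound 4 `Cc1nn(-c2nc(-c3ccc(Cl)c(Cl)c3)c(SC(C)C)s2)c(C(=O)O)c1-c1ccccc1Cl` has not yet been measured. It differs from compound 3 in a single place: 2-chlorophenyl in place of 2,6-dimethylpyridin-4-yl on an aromatic carbon. Within the data shown here, two measured steps bear on this change, since each of them replaced a six-membered aromatic ring of carbon only with the 2,6-dimethylpyridin-4-yl ring: a 240-fold lower number from compound 1 to compound 3 (2.38 log units; beyond the scatter) was large and a 6.2-fold lower number from compound 2 to compound 3 (0.79 log units; beyond the scatter) was modest. Going the other way, from the 2,6-dimethylpyridin-4-yl ring back to a ring of carbon only, should therefore raise the number. The 2-chlorophenyl ring of compound 4 is closer in kind to the 3-cyano-5-(trifluoromethyl)phenyl ring of compound 2 than to the 4-acetamidophenyl ring of compound 1, so a step of roughly the size seen for compound 2 is the expectation. Compound 4 is therefore expected to give about 3000 nM in this assay, within a range from 800 nM to 12000 nM. For compound 4 the expected step is a 5.2-fold higher number from compound 3 to compound 4 (0.71 log units; beyond the scatter), towards a higher number.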

Compound 4, half-maximal effective concentration: 13100 nM
Compound 4: middle estimate off by 4.4-fold (0.64 log units), on the low side, outside the stated range (above it).
By their numbers in this assay, from the lowest: compound 3; then compound 2; then compound 4; then compound 1.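

Replacing the 2,6-dimethylpyridin-4-yl ring with 2-chlorophenyl on this aromatic carbon gives a 23-fold higher number from compound 3 to compound 4 (1.35 log units; beyond the scatter) in this assay, so this small ring of carbon only does not match the 2,6-dimethylpyridin-4-yl ring here. The three compounds with a ring of carbon only also differ clearly among themselves, with a 3.6-fold higher number from compound 2 to compound 4 (0.56 log units; beyond the scatter) and an 11-fold lower number from compound 1 to compound 4 (1.03 log units; beyond the scatter), which shows that the groups on such a ring matter and not only the ring type; all three still stand above compound 3, and none of the four goes against this order. No measurement shown here explains these steps.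

Going by these compounds, it remains open whether the ring nitrogen or the two methyl groups of compound 3 matter more for its low number, a question that a pyridin-4-yl ring without the methyl groups would help to settle. A plain phenyl ring, or a methyl group in place of the chlorine of compound 4, would likewise show what the chlorine itself contributes.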